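The source may hold more compounds than are shown below. What is called first, only, known or untested is meant among the compounds shown, and "the series" means these compounds.

Measured so far:
compound 1 `CCCOc1ccc(C(CC(=O)O)c2ccccc2)cc1` — 4.8 uM
compound 2 `CCC(C)COc1ccc(C(CC(=O)O)c2ccccc2)cc1` — 0.3 uM

In a functional assay on HEK293 cells for agonist activity at Free fatty acid receptor 1 (Homo sapiens), read by calcium flux (a higher number here means that more compound is needed for the effect, a lower number that less compound is needed), compound 2 gives the lowest of the two numbers shown, the nearest being compound 1 at 4.8 uM. Compound 3 `CCC(CC)COc1ccc(C(CC(=O)O)c2ccccc2)cc1` differs from compound 2 by methyl in place of hydrogen on a saturated chain carbon, three bonds along the chain from an oxygen on an aromatic ring: the 2-methylbutyl becomes 2-ethylbutyl. For the measured compounds named here, the only step that bears on this is the chain growth at the same carbon, which gave a 16-fold lower number from compound 1 to compound 2 (1.20 log units; beyond the scatter). One further methyl on the same branch is expected to give a smaller step than that, in the same direction or flat within the scatter, so compound 3 is estimated at 0.2 uM (range 0.07 uM to 0.6 uM), a step of a 1.5-fold lower number from compound 2 to compound 3 (0.18 log units; within the scatter) in this assay.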

Compound 3, concentration for half-maximal effect: 0.64 uM
For compound 3 the middle estimate is 3.2-fold (0.51 log units) below the measured one; measured number outside the range, above it.
By their numbers in this assay, from the lowest: compound 2; then compound 3; then compound 1.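

In this assay, the branch does not keep improving with size: the change from 2-methylbutyl to 2-ethylbutyl gives a 2.1-fold higher number from compound 2 to compound 3 (0.33 log units; beyond the scatter) and so turns back part of the earlier drop. The larger branch still stands well ahead of the smaller chain, with a 7.5-fold lower number from compound 1 to compound 3 (0.88 log units; beyond the scatter) as the net result of the two changes. Nothing available accounts for this turn.

As far as these compounds go, whether a cyclopentyl ring in place of the two ethyl arms would lower the number again remains open. So does the response to a longer chain or a terminal hydroxyl at this position.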